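The compounds below may be only part of what the source reports. "The series", "measured", "known", "first", "only" and "open" are said of these compounds alone.

Compound 1 `COc1cc(C2=NN(C(C)=O)C(c3cccc(OC)c3OC)O2)cc(OC)c1OC` is the starting point. In a functional assay on BGC-823 cells (Homo sapiens) for antiproliferative activity, read by MTT assay, tested at 1 uM (a lower number here means a weaker effect, a higher number a stronger effect of the compound at the concentration tested), compound 1 gives 3.8%, the lowest of the two numbers available here. For the measured compounds named here, compound 2 `COc1cc(C(=O)N/N=C/c2ccccc2F)cc(OC)c1OC` is built on a different frame, and in this assay compound 2 gives 51.6%, a number well beyond the usual scatter above that of compound 1; no single-point step can be drawn between these two, since they differ in more than one place. Compound 3 `COc1cc(C2=NN(C(C)=O)C(c3ccc(F)c(F)c3)O2)cc(OC)c1OC` has not yet been measured. Compared with compound 1 it differs in one place: 3,4-difluorophenyl in place of 2,3-dimethoxyphenyl on a saturated ring carbon. Going by the values given here, no measured pair in this set shows the effect of such a swap, so the size of the step can only be guessed. Since compound 1 sits at the bottom with 3.8% and compound 2 with 51.6% shows that a clearly higher number is reachable in this assay, a small upward step is expected, one that may still stay within the scatter. The expected step is a number 11.2 percentage points higher from compound 1 to compound 3 (beyond the scatter). Compound 3 is estimated to give 15% in this assay, with a range from 2% to 45%.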

Compound 3, a percentage reported as inhibition, at one concentration (the size of the read-out at that concentration, not a potency): 18.3%
Beside the measured number, compound 3's estimate is 3.3 percentage points below it; the range from low to high includes it.
By their numbers in this assay, from the lowest: compound 1; then compound 3; then compound 2.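

In this assay, for the compounds shown here, this position responds to a change of aromatic group: 3,4-difluorophenyl in place of 2,3-dimethoxyphenyl on the saturated ring carbon gives a number 14.5 percentage points higher from compound 1 to compound 3 (beyond the scatter) and this is the first step in the set that can be read from a change in one place. The step is modest, but it marks this ring carbon as a place where the read-out moves, and compound 3 shows that the number can rise with no methoxy group on this aromatic ring. Nothing measured here gives a reason for the rise.

The step removes the two methoxy groups and brings in the two fluorines together, so it cannot say which of these matters, and a plain phenyl ring or a phenyl ring bearing a dimethylamino group at this carbon would help separate the two. On these data alone, the acetyl group on the ring is the same in compound 1 and compound 3, so what a longer chain such as propanoyl would do there also stays open.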